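Furan-3-yl in place of ethynyl: a second look

The source may hold more compounds than are shown below. What is called first, only, known or untested is meant among the compounds shown, and "the series" means these compounds.

Compound 2 `C#Cc1cn([C@@H]2O[C@H](CO)[C@@H](O)[C@H]2O)c2ncnc(N(C)C)c12` and compound 1 `CN(C)c1ncnc2c1c(-c1ccoc1)cn2[C@@H]1O[C@H](CO)[C@@H](O)[C@H]1O` share one core and differ in a single group. In an ADME assay on MRC5 cells (Homo sapiens), read by MTT assay, with a stated time of 72 h (a lower number here means a stronger inhibitor, a higher number a weaker inhibitor), compound 2 gives 36100 nM. For compound 1 only a limit of the assay is reached, namely > 100000 nM. The change between them is furan-3-yl in place of ethynyl on an aromatic carbon, and it made an at least 2.7-fold higher number from compound 2 to compound 1 (0.44 log units; beyond the scatter). This rests on (the limit of > 100000 nM in this assay, at which 2 of the 3 values shown sit), since the value of compound 1 is a limit and the true step could be larger.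

Compound 3 `C#Cc1cn([C@@H]2O[C@H](CO)[C@@H](O)[C@H]2O)c2nc(N)nc(OC)c12` carries the ethynyl group on a different core; the difference between the core of compound 3 and the core of compound 2 is not broken down here. In this assay compound 3 reaches only a limit of the assay, > 100000 nM. Compound 4 `COc1nc(N)nc2c1c(-c1ccoc1)cn2[C@@H]1O[C@H](CO)[C@@H](O)[C@H]1O` is the furan-3-yl partner of compound 3, and the change is furan-3-yl in place of ethynyl on an aromatic carbon, which is the same change as from compound 2 to compound 1.

Because the earlier step was an at least 2.7-fold higher number from compound 2 to compound 1 (0.44 log units; beyond the scatter) and pointed toward weaker inhibition, and because the limit of > 100000 nM in this assay, at which 2 of the 3 values shown sit, shows that two of the three values already sit at that limit, compound 4 is expected to stay at or beyond the same limit. The step is estimated as a step that the limit leaves unreadable from compound 3 to compound 4. Compound 4 is therefore estimated at 200000 nM, most likely reported as a limit rather than a number, with an expected span from 80000 nM to 600000 nM.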

Compound 4, half-maximal inhibitory concentration: > 100000 nM
Compound 4 gave a limit, no number (the forecaster's own chance of this, stated with the estimate: 90%); the middle value is on the limit's open side.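

In this assay compound 4 gives > 100000 nM as a limit of the assay, not a number. Compound 3 stands at a limit as well, so no step can be read between compound 3 and compound 4: the limit of > 100000 nM in this assay, at which 3 of the 4 values shown sit.

The compounds shown leave open how far past the limit compound 3 and compound 4 lie, and whether furan-3-yl in place of ethynyl changes the result on this core as it does on the core of compound 2.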